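Trifluoromethoxy in Place of Cyano: What Compound 4 Might Give

The compounds below may be only part of what the source reports. "The series", "measured", "known", "first", "only" and "open" are said of these compounds alone.

Of the compounds shown here, three sharing one core have been measured in an assay on isolated protein for inhibition of Rho-associated protein kinase 1 (Homo sapiens), read by scintillation counting, radiometric assay and 33P incorporation, with a stated time of 40 min, in the presence of a further agent that is not named here; on this read-out lower numbers stand for stronger inhibition and higher numbers for weaker inhibition. Compound 1 `O=C(COc1ccc2c(=O)ccoc2c1)Nc1cccc(NC(=O)c2ccccc2)c1` gives 120 nM, compound 2 `CC(C)(C)c1ccc(C(=O)Nc2cccc(NC(=O)COc3ccc4c(=O)ccoc4c3)c2)cc1` gives 165 nM, and compound 3 `N#Cc1ccc(C(=O)Nc2cccc(NC(=O)COc3ccc4c(=O)ccoc4c3)c2)cc1` gives 123 nM. Compound 3 holds the second highest of the three numbers, with compound 1 nearest and compound 2 furthest, both within the scatter. The steps on this ring have all been small: a 1.4-fold higher number from compound 1 to compound 2 (0.14 log units; within the scatter), a 1.0-fold higher number from compound 1 to compound 3 (0.01 log units; within the scatter) and a 1.3-fold lower number from compound 2 to compound 3 (0.13 log units; within the scatter), every one within the scatter, whether hydrogen, tert-butyl or cyano sits there.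

Compound 4 `O=C(COc1ccc2c(=O)ccoc2c1)Nc1cccc(NC(=O)c2ccc(OC(F)(F)F)cc2)c1` differs from compound 3 by trifluoromethoxy in place of cyano on an aromatic carbon. Since hydrogen, tert-butyl and cyano at this place gave numbers within the scatter of each other, trifluoromethoxy is expected to do likewise, with no step beyond the scatter in this assay. The step from compound 3 to compound 4 is therefore estimated at a 1.1-fold higher number from compound 3 to compound 4 (0.02 log units; within the scatter). Compound 4 is expected to give about 130 nM, between 65 nM and 260 nM.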

Compound 4, half-maximal inhibitory concentration: 869 nM
Compound 4: middle estimate off by 6.7-fold (0.83 log units), on the low side, and the stated range ends below it.
By their numbers in this assay, from the lowest: compounds 1, 3 and 2 (each within the scatter of the next); then compound 4.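

Up to this point, the place para to a large group had looked indifferent to its substituent in this assay, but trifluoromethoxy shows that it can respond: the change gives a 7.1-fold higher number from compound 3 to compound 4 (0.85 log units; beyond the scatter), and the same group gives a 5.3-fold higher number from compound 2 to compound 4 (0.72 log units; beyond the scatter) and a 7.2-fold higher number from compound 1 to compound 4 (0.86 log units; beyond the scatter). The tolerance seen with hydrogen, tert-butyl and cyano therefore holds for those three groups and does not extend to every group at this place. No available evidence bears on what lies behind this step.

The compounds shown leave open whether the higher number goes with the oxygen or with the fluorine atoms of the entering group, a question that methoxy and trifluoromethyl at the same place would address. They also leave open how an amine or a carboxylic acid would behave there.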